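A few compounds are considered here, and "the series" means these few. Any claim that something is new, unique, unknown or untested is made for them only; others in the source may bear on it.

Going by the values given here, in a functional assay (strain AB) with Danio rerio as the target, read by microscopy, with a stated time of 1 h (on this read-out higher numbers stand for an effect only at larger amounts of compound and lower numbers for an effect already at smaller amounts), compound 1 `CCN1CCc2c(sc(NC(=O)Nc3cccc(C)c3)c2C(N)=O)C1` gives 13000 nM, the only actual number among the measured compounds. Compound 2 `CCN1CCc2c(sc(NC(=O)CN3CCCCC3)c2C(N)=O)C1` is reported only as a limit, > 25000 nM. Compound 3 `CCN1CCc2c(sc(NC(=O)[C@@H]3CCCN3)c2C(N)=O)C1` is likewise reported only as a limit, > 25000 nM.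

Compound 4 `CCN1CCc2c(sc(NC(=O)NCc3cccc(Cl)c3)c2C(N)=O)C1` differs from compound 1 at a single place: 3-chlorobenzyl in place of 3-methylphenyl on an amide-type nitrogen. It carries 3-chlorobenzyl in place of 3-methylphenyl on an amide-type nitrogen.

Among the compounds with values here, two measured steps bear on this only indirectly, since both replace the whole (3-methylphenyl)amino group on the carbonyl carbon. One is an at least 1.9-fold higher number from compound 1 to compound 2 (0.28 log units; that floor lies within the scatter), and the other is an at least 1.9-fold higher number from compound 1 to compound 3 (0.28 log units; that floor lies within the scatter). Within the data shown here, compound 4 keeps that amide-type nitrogen, and no measured step changes only the group on it, so neither step gives a direction. Compound 1, at 13000 nM, therefore remains the anchor for the expectation.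

The estimated change is a 1.1-fold lower number from compound 1 to compound 4 (0.03 log units; within the scatter), and no shift beyond the scatter is expected. For compound 4, the expected value is 12000 nM, with an estimated range from 4000 nM to 25000 nM.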

Compound 4, half-maximal effective concentration: > 25000 nM
Compound 4 was reported as a limit (the forecaster's own chance of this, stated with the estimate: 30%); middle value at least 2.0-fold (0.31 log units) from the limit.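

In this assay compound 4 is reported only as a limit, > 25000 nM. Putting 3-chlorobenzyl in place of 3-methylphenyl on the amide-type nitrogen gives an at least 1.9-fold higher number from compound 1 to compound 4 (0.28 log units; that floor lies within the scatter), the first step shown that keeps this nitrogen and changes only the group on it. That single change gives no reading better than compound 1, and it ends at the same limit as the two replacements of the whole (3-methylphenyl)amino group, so the true size of the step stays hidden and compound 1 remains the only compound with an actual number: the limit of > 25000 nM in this assay, at which 3 of the 4 values shown sit.

The compounds shown leave open whether the chlorine or the extra carbon of the benzyl group matters more at this nitrogen. A 3-chlorophenyl or a 3-methylbenzyl group there would separate these two parts of the change.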